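A few compounds are considered here, and "the series" means these few. Any claim that something is new, unique, unknown or untested is made for them only; others in the source may bear on it.

Of the compounds shown here, three sharing one core have been measured in a functional assay on SGC-7901 cells (Homo sapiens) for inhibition, read by MTT assay, with a stated time of 72 h; a lower number here means a stronger inhibitor, a higher number a weaker inhibitor. Compound 1 `O=C1Nc2ccccc2/C1=C\C(=O)c1cccc(Cl)c1` gives 8400 nM, compound 2 `O=C1Nc2ccccc2/C1=C\C(=O)c1ccccc1F` gives 17400 nM, and compound 3 `CC(=O)Nc1cccc(C(=O)/C=C2/C(=O)Nc3ccccc32)c1` gives 14100 nM. Compound 3 therefore lies within the scatter of both other compounds, so it cannot be ranked firmly against either.

Compound 4 `C=CC(=O)Nc1cccc(C(=O)/C=C2/C(=O)Nc3ccccc32)c1` departs from compound 3 in a single place: vinyl in place of methyl on a carbonyl carbon. In words, vinyl takes the place of methyl on a carbonyl carbon, which turns acetamido into (vinylcarbonyl)amino.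

Among the compounds with values here, no measured compound carries this exact change. Within the data shown here, the only measured step that bears on it is a 1.7-fold higher number from compound 1 to compound 3 (0.22 log units; within the scatter), which replaces chloro with acetamido on an aromatic carbon. That single step stayed small, and it says nothing directly about a vinyl group. A shift beyond the scatter is therefore not expected in this assay, though the range must stay wide. The estimated step is a 1.4-fold lower number from compound 3 to compound 4 (0.15 log units; within the scatter). For compound 4 the expected value is 10000 nM, with an estimated range from 3500 nM to 25000 nM.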

Compound 4, half-maximal inhibitory concentration: 5700 nM
For compound 4 the middle estimate is 1.8-fold (0.24 log units) above the measured one, and the stated range covers the measured number.
By their numbers in this assay, from the lowest: compounds 4, 1, 3 and 2 (each within the scatter of the next, the first and the last beyond it).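

In this assay, within the data shown here, vinyl in place of methyl on a carbonyl carbon gives a 2.5-fold lower number from compound 3 to compound 4 (0.39 log units; beyond the scatter) and, though modest, this is the first step to lie beyond the scatter, so the read-out does respond to the group at this place. Compared with the chloro compound, the (vinylcarbonyl)amino group gives a 1.5-fold lower number from compound 1 to compound 4 (0.17 log units; within the scatter) and stays within the scatter, so compound 4 cannot be firmly separated from compound 1. Nothing available here explains the step from methyl to vinyl.

As far as these compounds go, it remains open whether ethyl, which lacks the double bond of vinyl, would read like methyl or like vinyl on this carbonyl carbon. A longer chain such as propyl, or an amine at the same place, is equally untested by the compounds shown.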